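The source may report more compounds than this note shows. Statements on the series, on what has been measured and on what is new or still open speak of the compounds shown alone.

Three compounds have numbers in an assay on CHO-K1 cells for displacement of a labelled ligand from prostaglandin E2 receptor EP1 subtype (Homo sapiens), read by scintillation counting, with a stated time of 45 min (a lower number here means a stronger inhibitor, a higher number a weaker inhibitor), so far. Compound 1 `CCCc1cc2cc(Cl)cc(Cn3nc(C(=O)O)cc3C)c2o1` gives 25.1 nM. Compound 2 `CO[C@H]1CC[C@H](NC(=O)c2cc(C)n(Cc3cc(Cl)cc4cc(C(C)C)oc34)n2)CC1` gives 316 nM. Compound 3 `Cc1cc(C(=O)NN2CCOCC2)nn1Cc1cc(Cl)cc2cc(-c3ccccc3)oc12` gives 10 nM, the lowest of the three numbers: compound 1 stands higher, beyond the scatter, and compound 2 higher still, also beyond the scatter. Compound 3 therefore counts as the strongest inhibitor among the measured set.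

Compound 4 `Cc1cc(C(=O)NC(C)C)nn1Cc1cc(Cl)cc2cc(-c3ccccc3)oc12` has not yet been measured in this assay. It differs from compound 3 in one place: isopropyl in place of morpholin-4-yl on an amide-type nitrogen. The shared core of compounds 3 and 4, including the phenyl-bearing benzofuran part and the chloro substituent, stays the same.

For the measured compounds named here, no pair of measured compounds shows this exchange, so there is no measured step to lean on. The amide substituents among the measured compounds vary widely and sit on different cores, so what remains is a guess. Replacing a ring that carries two hydrogen-bond acceptors with a plain three-carbon group is a change of moderate size, and a small loss, close to or just beyond the scatter, seems the likeliest outcome. The estimated step from compound 3 to compound 4 in this assay is a 2.2-fold higher number from compound 3 to compound 4 (0.34 log units; beyond the scatter). For compound 4 the expected value in this assay is 22 nM, with a plausible range from 6 nM to 90 nM.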

Compound 4, half-maximal inhibitory concentration: 10 nM
Estimate against measurement, compound 4: 2.2-fold (0.34 log units) above, and the stated range covers the measured number.
By their numbers in this assay, from the lowest: compounds 3 and 4 (each within the scatter of the next); then compound 1; then compound 2.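

In this assay, placing isopropyl instead of morpholin-4-yl on the amide-type nitrogen gives no change at the digits printed from compound 3 to compound 4 (within the scatter), and this is the only direct reading of a single exchange among the compounds shown. With the shared core held fixed, the morpholin-4-yl ring and its two hydrogen-bond acceptors can therefore give way to a smaller group of three carbons, with no ring and no acceptors, without a measurable shift in this assay. Nothing measured here explains why the number stays in place.

From the compounds shown here alone, this single pair cannot show how much variety the amide-type nitrogen accepts, so it remains open whether a longer chain such as n-hexyl, or a chain ending in an amine, would also leave the number unchanged on the shared core of compounds 3 and 4. Going by these compounds, it also remains open whether the same exchange would behave in the same way on the different cores of compound 1 and compound 2, which carry propyl and isopropyl where compounds 3 and 4 carry phenyl.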